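The source may hold more compounds than are shown below. What is called first, only, known or untested is meant among the compounds shown, and "the series" means these compounds.

Working notes on the series. In an ADME assay on microsomes from liver (Homo sapiens) for metabolic stability, read by LC-MS, with a stated time of 30 min, tested at 1 uM (on this read-out lower numbers stand for a less stable compound and higher numbers for a more stable compound), compound 1 (`CC(C)(C)NCc1cc(Cl)cc(Nc2nc3cc(F)c(F)cc3n2Cc2ccc(C(F)(F)F)cc2)c1O`) gives 89%. Among the compounds with values here, the only other measured member, compound 2 (`CCNCc1cc(C)cc(Nc2nc3ccccc3n2Cc2ccc(C(F)(F)F)cc2)c1O`), gives 98%, and the two values lie within the scatter of each other. Compound 3 (`Cc1cc(CNC(C)(C)C)c(O)c(Nc2nc3cc(F)c(F)cc3n2Cc2ccc(C(F)(F)F)cc2)c1`) is still to be measured in this assay. It departs from compound 1 by a single change: methyl in place of chloro on an aromatic carbon, para to a hydroxy group. Within the data shown here, no measured pair isolates this change, so the expectation has no direct step behind it. Compound 2 also carries a methyl para to its hydroxy group and gives 98%, so no loss is expected from the methyl. The estimated step is a number 3 percentage points higher from compound 1 to compound 3 (within the scatter), which is not expected to exceed the scatter. For compound 3 the expected value is 92%, with an estimated range of 80% to 100%.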

Compound 3, percent of the compound remaining: 90%
Compound 3: middle estimate off by 2 percentage points, on the high side; the range from low to high includes it.
By their numbers in this assay, from the lowest: compounds 1, 3 and 2 (each within the scatter of the next).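

Methyl in place of chloro on an aromatic carbon, para to a hydroxy group, now has a direct step in this assay: a number 1 percentage points higher from compound 1 to compound 3 (within the scatter). Within the data shown here, this is the first pair that isolates the change, and with the ((tert-butyl)amino)methyl group and the rest of the core of compound 1 held fixed, the read-out does not separate chloro from methyl at this position. No measurement at hand bears on why the two groups read alike.

Going by these compounds, whether a methoxy group, an amine or a carboxylic acid at this position would also read alike stays open. Equally open, on these data alone, is whether methyl and chloro would still read alike with a longer chain in place of the ((tert-butyl)amino)methyl group.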